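The compounds below may be only part of what the source reports. "The series", "measured", "known", "first", "only" and "open" are said of these compounds alone.

Measured so far in an assay on HEK293 cells for binding affinity to Neuronal acetylcholine receptor; alpha4/beta2 (Homo sapiens); a lower number here means a stronger inhibitor, a higher number a weaker inhibitor:
- compound 1, `c1nc2cc3c(cc2[nH]1)C1CNCC3C1`: 0.15 nM
- compound 2, `CC(C)Cn1cnc2cc3c(cc21)C1CNCC3C1`: 0.3 nM

Among the compounds with values here, compound 2 stands within the scatter of compound 1, the only other compound measured, so the two numbers cannot be told apart. Within the data shown here, the one measured step, a 2.0-fold higher number from compound 1 to compound 2 (0.30 log units; within the scatter), shows that putting a group on the aromatic nitrogen of the shared core left the binding essentially unchanged.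

Compound 3, `c1ccc(-n2cnc3cc4c(cc32)C2CNCC4C2)cc1`, differs from compound 2 in a single place: phenyl in place of isobutyl on an aromatic nitrogen. The step from compound 1 to compound 2 is the only one that bears on this change, since it also concerns a substituent on the same aromatic nitrogen, and it was within the scatter. Among the measured compounds shown here, no measured step involves a phenyl group, so the expectation rests on that one step alone. Compound 3 is therefore expected to show a step of a 1.7-fold higher number from compound 2 to compound 3 (0.22 log units; within the scatter), that is, no change beyond the scatter, with the range left wide to allow for the larger group. The estimate for compound 3 in this assay is 0.5 nM, between 0.15 nM and 2 nM.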

Compound 3, inhibition constant: 0.14 nM
Compound 3: middle estimate off by 3.6-fold (0.55 log units), on the high side; the measured number lies below the stated range.
By their numbers in this assay, from the lowest: compounds 3, 1 and 2 (each within the scatter of the next, the first and the last beyond it).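

In this assay, within the data shown here, the phenyl group on the aromatic nitrogen gives a 2.1-fold lower number from compound 2 to compound 3 (0.33 log units; beyond the scatter) and so goes beyond the scatter, a modest step that is the first sign that the choice of group at this position can register at all. Set against the hydrogen of the shared core, the same phenyl gives a 1.1-fold lower number from compound 1 to compound 3 (0.03 log units; within the scatter) and stays within the scatter, so a six-membered aromatic ring on this nitrogen costs no measurable binding. Nothing available bears on why phenyl and isobutyl part here.

From the compounds shown here alone, whether a longer chain, a benzyl group or a pyridine ring on this nitrogen would hold binding at this level remains open. So does the question of whether a phenyl ring carrying an amine or a carboxylic acid would leave the number unchanged.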